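Removing a Methyl From a Hydroxylamine Nucleoside

The compounds below may be only part of what the source reports. "The series", "measured", "known", "first", "only" and "open" are said of these compounds alone.

Compound 1 `CC(C)(C)OC(=O)NOc1nc(N)nc2c1ncn2[C@@H]1O[C@H](CO)[C@@H](O)[C@@]1(C)O` gives > 100000 nM in an ADME assay on CCRF-CEM cells (Homo sapiens) for cytotoxicity, read by trypan blue exclusion, with a stated time of 6 days; on this read-out higher numbers stand for lower toxicity in this test and lower numbers for higher toxicity in this test.
Compound 2 `C[C@@]1(O)[C@H](O)[C@@H](CO)O[C@H]1n1cnc2c(ONC(=O)OCc3ccccc3)nc(N)nc21` gives > 100000 nM in this assay.
Compound 3 `CONc1nc(N)nc2c1ncn2[C@@H]1O[C@H](CO)[C@@H](O)[C@@]1(C)O` gives > 100000 nM in this assay.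

Each of these values is a limit of this assay, not a number. Compound 3 therefore stands with the other two at the limit of > 100000 nM in this assay, at which 3 of the 3 values shown sit. Compound 4 `C[C@@]1(O)[C@H](O)[C@@H](CO)O[C@H]1n1cnc2c(NO)nc(N)nc21` differs from compound 3 by hydrogen in place of methyl on an oxygen. The two measured steps, a step that the two limits leave unreadable from compound 1 to compound 2 and a step that the two limits leave unreadable from compound 1 to compound 3, are both hidden by limits, so no size and no direction can be read from them. Because all three results sit at the limit of > 100000 nM in this assay, at which 3 of the 3 values shown sit, compound 4 is expected to stay there as well, with an estimated step of a number no higher from compound 3 to compound 4 (the limit leaves the size open) that would not exceed the scatter. Compound 4 is thus estimated at 100000 nM, in the range 30000 nM to 300000 nM.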

Compound 4, half-maximal cytotoxic concentration: > 100000 nM
Compound 4: no number, only a limit; the forecaster's own chance of this, stated with the estimate: 85%; the middle value sits exactly at the limit.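

Compound 4 gives only a limit, so neither its step from compound 3 nor its step from compound 1 can be read. The compounds shown leave open at what concentration, if any, each would turn toxic in this assay.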